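Hydroxycarbamoyl end group: from compound 2 to compound 3

This account rests on a few compounds, and the source may have more. Where it says the series, first, only, none or still open, it means among the compounds named here.

Measured in a functional assay on A549 cells (Homo sapiens) for inhibition, read by MTT assay, with a stated time of 72 h (a higher number here means a weaker inhibitor, a lower number a stronger inhibitor), so far:
Compound 1 `Nc1nc2cc(-c3nn(CCC(=O)NO)c4ncnc(N)c34)ccc2o1` gives > 150000 nM as a limit
Compound 2 `CNC(=O)CCCCCCCn1nc(-c2ccc3oc(N)nc3c2)c2c(N)ncnc21` gives 8360 nM as a number

Among the measured compounds shown here, compound 2 holds the only number so far, the other value being a limit. Compound 3 `Nc1nc2cc(-c3nn(CCCCCCC(=O)NO)c4ncnc(N)c34)ccc2o1` carries hydroxycarbamoyl in place of (methylcarbamoyl)methyl on a saturated chain carbon, six bonds along the chain from an aromatic nitrogen. For the measured compounds named here, one measured step bears on this: an at least 17-fold lower number from compound 1 to compound 2 (1.25 log units; beyond the scatter) in this assay is large, but there hydroxycarbamoyl leaves from only two bonds along the chain, so it transfers poorly in size or direction. Compound 3 keeps hydroxycarbamoyl six bonds along the chain, so it is not expected to share the limit of compound 1. The expected change is a 3.3-fold lower number from compound 2 to compound 3 (0.52 log units; beyond the scatter) as a modest move, weakly supported. For compound 3 the estimate is 2500 nM with an expected range of 400 nM to 12000 nM in this readout.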

Compound 3, half-maximal inhibitory concentration: 33000 nM
Compound 3: middle estimate off by 13-fold (1.12 log units), on the low side; measured number above the stated range.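

In this assay, hydroxycarbamoyl in place of (methylcarbamoyl)methyl, six bonds along the chain from an aromatic nitrogen, gives a 3.9-fold higher number from compound 2 to compound 3 (0.60 log units; beyond the scatter), so this end group brings no gain over the methylcarbamoyl end at this place. With the hydroxycarbamoyl end kept, 4-(hydroxycarbamoyl)butyl in place of hydroxycarbamoyl gives an at least 4.5-fold lower number from compound 1 to compound 3 (0.65 log units; beyond the scatter), so chain length alone changes the reading in this pair. The size of that step is only a lower bound, since compound 1 stands at a limit of the assay: the limit of > 150000 nM in this assay, at which 1 of the 3 values shown sits.

Still open, going by these compounds, is whether a carboxylic acid or a primary amide at the end of the compound 3 chain would read nearer compound 2 or compound 3. How a longer chain carrying hydroxycarbamoyl would read also remains unsettled.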